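The source may hold more compounds than are shown below. What is called first, only, known or untested is meant among the compounds shown, and "the series" means these compounds.

Measured compounds in an assay on HEK293-A cells for agonist activity at probable G-protein coupled receptor 34 (Mus musculus), with a stated time of 1.5 h; a higher number here means a larger maximal response, a lower number a smaller maximal response:
- compound 1, `N[C@@H](COP(=O)(O)O[C@@H]1CCCO[C@@H]1COC(=O)CCc1ccccc1OCc1cccc(Oc2ccc(Cl)cc2)c1)C(=O)O`, gives 16.6%
- compound 2, `N[C@@H](COP(=O)(O)O[C@@H]1CCCO[C@@H]1COC(=O)CCc1ccccc1OCc1cccc(Oc2ccccc2)c1)C(=O)O`, gives 14.8%
- compound 3, `CCCCCCCC/C=C\CCCCCCCC(=O)O[C@H]1CCCO[C@@H]1COP(=O)(O)OC[C@H](N)C(=O)O`, is reported as "not active" (no number reported), without a number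

Among the compounds with values here, compound 2 stands alongside compound 1, the only other compound with a numerical result: the step of a number 1.8 percentage points lower from compound 1 to compound 2 (within the scatter) keeps the two within the usual scatter, so the two values cannot be told apart. Compound 3 carries a different ester chain and gives no number in this assay.

Compound 4, `Cc1ccc(Oc2cccc(COc3ccccc3CCC(=O)OC[C@H]3OCCC[C@H]3OP(=O)(O)OC[C@H](N)C(=O)O)c2)cc1`, is the next compound to be measured. It differs from compound 2 by methyl in place of hydrogen on an aromatic carbon.

Within the data shown here, the one measured step that bears on this change is the one from compound 1 to compound 2, where a small substituent on the same distant aromatic ring was exchanged for hydrogen; that step stayed within the scatter. A further small substituent on that ring is therefore expected to move this assay by no more than the scatter, which gives an expected step of a number 0.7 percentage points higher from compound 2 to compound 4 (within the scatter).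

Compound 4 is accordingly estimated to give 15.5%, with a range from 7% to 25%.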

Compound 4, largest response reached (Emax), in percent of the reference or control that the assay uses: 15.2%
Compound 4: middle estimate off by 0.3 percentage points, on the high side; low and high end bracket the measured number.
By their numbers in this assay, from the lowest: compounds 2, 4 and 1 (each within the scatter of the next).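

With methyl, this place para to a large group has now carried three different substituents, and in this assay the change gives a number 0.4 percentage points higher from compound 2 to compound 4 (within the scatter) and a number 1.4 percentage points lower from compound 1 to compound 4 (within the scatter). Hydrogen, chloro and methyl on this aromatic carbon therefore cannot be told apart by their maximal response, so exchanging chloro for methyl, a step the earlier compounds did not cover, also leaves the read-out within the scatter. No supporting evidence is available to account for this result.

As far as these compounds go, it remains open whether an amine, a carboxylic acid or a longer chain at this place would shift the response in this assay beyond the scatter. The compounds shown also leave open whether the phenoxy group itself is needed for a measurable response.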